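Aminophenyl to dimethoxyphenyl on the enone ketone

A few compounds are considered here, and "the series" means these few. Any claim that something is new, unique, unknown or untested is made for them only; others in the source may bear on it.

Measured so far:
compound 1 `COc1cc(-c2cc(/C=C/C(=O)c3ccc(N)cc3)[nH]n2)cc(OC)c1OC` — 85%
compound 2 `COc1ccc(-c2cc(/C=C/C(=O)c3ccc(N)cc3)[nH]n2)cc1` — 92%

In a functional assay on BT-549 cells (Homo sapiens) for cytotoxicity, read by sulforhodamine B assay, with a stated time of 48 h, tested at 0.01 uM (on this read-out higher numbers stand for a weaker effect at the one concentration tested and lower numbers for a stronger effect), compound 1 gives 85%, and compound 2 gives 92%; the two values lie within the scatter of each other, so neither can be set apart. Compound 3 `COc1ccc(C(=O)/C=C/c2cc(-c3cc(OC)c(OC)c(OC)c3)n[nH]2)cc1OC` is not yet measured. Its change from compound 1 is 3,4-dimethoxyphenyl in place of 4-aminophenyl on a carbonyl carbon. Among the measured compounds shown here, no measured pair shows this change, so its size is unknown. Compound 3 is expected to stay close to compound 1, with a step of a number 3 percentage points higher from compound 1 to compound 3 (within the scatter) that is not expected to pass beyond the scatter. The estimate for compound 3 is 88%, within 74% to 100%.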

Compound 3, a percentage reported as activity, at one concentration (the size of the read-out at that concentration, not a potency): 95%
Compound 3: middle estimate off by 7 percentage points, on the low side, within the range that was stated.
By their numbers in this assay, from the lowest: compounds 1, 2 and 3 (each within the scatter of the next).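

In this assay, the first step readable at this position, on a carbonyl carbon, is a number 10 percentage points higher from compound 1 to compound 3 (within the scatter) for 3,4-dimethoxyphenyl in place of 4-aminophenyl. At the one concentration tested, this exchange of aryl groups therefore cannot be told apart from no change. No evidence on hand bears on this result.

Going by these compounds, it remains open whether a morpholine or a carboxylic acid on the phenyl ring at this position would give a step beyond the scatter. On these data alone, a simple methyl on the carbonyl carbon, with no aryl ring, is equally open.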